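Cytotoxicity notes: chloro in place of benzyloxy

This account rests on a few compounds, and the source may have more. Where it says the series, first, only, none or still open, it means among the compounds named here.

Compound 1 `O=C(/C=C/c1ccc2c(c1)B(O)OC2)c1ccc(OCc2ccccc2)cc1` was run in an ADME assay on L929 cells (Mus musculus) for cytotoxicity, read by resazurin assay, with a stated time of 72 h; a higher number here means a weaker inhibitor, a lower number a stronger inhibitor. In this assay compound 1 gives > 10 ug/mL, which is a limit of the assay and not a number. Compound 2 `COc1cccc(C(=O)CCc2ccc3c(c2)B(O)OC3)c1` gives > 10 ug/mL in this assay, again a limit. Compound 3 `Cc1ccc(C(=O)/C=C/c2ccc3c(c2)B(O)OC3)cc1C` gives > 10 ug/mL in this assay, also a limit. So far (the limit of > 10 ug/mL in this assay, at which 3 of the 3 values shown sit), and compound 1 cannot be ranked against its companions. Compound 4 `O=C(/C=C/c1ccc2c(c1)B(O)OC2)c1ccc(Cl)cc1` differs from compound 1 by chloro in place of benzyloxy on an aromatic carbon. Among the compounds with values here, no step between measured compounds exists to judge this change. With every neighbour at the limit, no movement beyond the usual scatter in this assay is expected here. Compound 4 is therefore expected at 15 ug/mL (range 7 ug/mL to 40 ug/mL), an expected step that the limit leaves unreadable from compound 1 to compound 4.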

Compound 4, half-maximal inhibitory concentration: > 10 ug/mL
Compound 4 gave a limit, no number (the forecaster's own chance of this, stated with the estimate: 75%); the middle value lies beyond the limit too.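

No step can be read from compound 1 to compound 4, as both values are limits and not numbers: the limit of > 10 ug/mL in this assay, at which 4 of the 4 values shown sit.

The compounds shown leave open whether chloro and benzyloxy differ at all in this assay.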